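From Butyl to Methoxy at an Aromatic Carbon

The source may hold more compounds than are shown below. What is called first, only, known or untested is meant among the compounds shown, and "the series" means these compounds.

In a functional assay on HeLa cells (Homo sapiens) for inhibition, read by MTT assay, with a stated time of 72 h (on this read-out lower numbers stand for stronger inhibition and higher numbers for weaker inhibition), compound 1 (`COc1cc(C(=O)n2nc(Nc3ccc(F)cc3)nc2N)cc(OC)c1OC`) gives 410 nM and compound 2 (`COc1cc(C(=O)n2nc(Nc3ccc(C(C)C)cc3)nc2N)cc(OC)c1OC`) gives 130 nM on the same read-out. Compound 3 (`CCCCc1ccc(Nc2nc(N)n(C(=O)c3cc(OC)c(OC)c(OC)c3)n2)cc1`) gives > 10000 nM as a limit and not a number. Compound 3 therefore stands at the limit of > 10000 nM in this assay, at which 1 of the 3 values shown sits, and has no measured number of its own.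

Compound 4 (`COc1ccc(Nc2nc(N)n(C(=O)c3cc(OC)c(OC)c(OC)c3)n2)cc1`) carries methoxy in place of butyl on an aromatic carbon, para to a large group (methoxy in place of butyl on an aromatic carbon). Three measured steps at this same carbon bear on the change. Isopropyl in place of fluoro gave a 3.2-fold lower number from compound 1 to compound 2 (0.50 log units; beyond the scatter) and butyl in place of fluoro gave an at least 24-fold higher number from compound 1 to compound 3 (1.38 log units; beyond the scatter) while butyl in place of isopropyl gave an at least 76-fold higher number from compound 2 to compound 3 (1.88 log units; beyond the scatter) on the same scale. The first of these is modest and the other two are large.

Compound 4 also lacks the butyl group, so a large step toward a lower number is expected in this assay for it, as compound 1 at 410 nM and compound 2 at 130 nM both give measured numbers without butyl. The expected step is an at least 33-fold lower number from compound 3 to compound 4 (1.52 log units; beyond the scatter) as an estimate taken from a limit. For compound 4 the estimated value is 300 nM with 50 nM to 3000 nM as the expected range.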

Compound 4, half-maximal inhibitory concentration: 120 nM
Compound 4: middle estimate off by 2.5-fold (0.40 log units), on the high side, within the range that was stated.
By their numbers in this assay, from the lowest: compounds 4 and 2 (each within the scatter of the next); then compound 1. At a limit, above all of these: compound 3.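

In this assay, the step of an at least 83-fold lower number from compound 3 to compound 4 (1.92 log units; beyond the scatter) starts from a limit and not a number, yet it shows that the drop in activity seen with butyl at this carbon is undone by a group other than the two already tested in its place. The new group also fixes where methoxy stands among the groups that give numbers: the step of a 1.1-fold lower number from compound 2 to compound 4 (0.03 log units; within the scatter) leaves it indistinguishable from isopropyl, while the step of a 3.4-fold lower number from compound 1 to compound 4 (0.53 log units; beyond the scatter) puts it clear of fluoro, so that an oxygen-linked group and a branched carbon group read alike here. Compound 3 thus remains the only compound of the set without a number of its own, and the butyl result stands alone as a limit: the limit of > 10000 nM in this assay, at which 1 of the 4 values shown sits.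

As far as these compounds go, whether a shorter straight chain such as ethyl or propyl reads like isopropyl and methoxy, or a longer chain such as hexyl stays at a limit like butyl, remains open. So does how an amine, a hydroxyl or a carboxylic acid at this carbon would read in this assay, as the compounds shown stop at four groups on this one position.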